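The compounds below may be only part of what the source reports. "The series", "measured", "known", "first", "only" and "open" are said of these compounds alone.

Compound 3 `COc1cccc(C(=O)/C=C/c2ccc3c(c2)B(O)OC3)c1` is one of three close relatives built on a shared core, each carrying a different group on its aromatic ring. In a functional assay on HCT-116 cells (Homo sapiens) for cytotoxicity, read by MTT assay, with a stated time of 48 h (on this read-out higher numbers stand for weaker inhibition and lower numbers for stronger inhibition), compound 3 gives 5000 nM. Its number is the lowest of the three, yet compound 1 `O=C(/C=C/c1ccc2c(c1)B(O)OC2)c1cccc(F)c1` gives 6700 nM and compound 2 `O=C(/C=C/c1ccc2c(c1)B(O)OC2)c1cccc(O)c1` gives 6500 nM, and every step among them stays within the scatter: a 1.0-fold lower number from compound 1 to compound 2 (0.01 log units; within the scatter), a 1.3-fold lower number from compound 1 to compound 3 (0.13 log units; within the scatter), a 1.3-fold lower number from compound 2 to compound 3 (0.11 log units; within the scatter). Compound 4 `COCOc1cccc(C(=O)/C=C/c2ccc3c(c2)B(O)OC3)c1` differs from compound 3 by methoxy in place of hydrogen on a saturated chain carbon bound to an oxygen on an aromatic ring. The step nearest in kind is a 1.3-fold lower number from compound 2 to compound 3 (0.11 log units; within the scatter), which changed little. For compound 4 in this assay a step of a 1.1-fold higher number from compound 3 to compound 4 (0.04 log units; within the scatter) is expected, none beyond the scatter. The estimate for compound 4 is 5500 nM, between 2500 nM and 12000 nM.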

Compound 4, half-maximal inhibitory concentration: 13300 nM
The estimate for compound 4 lay 2.4-fold (0.38 log units) below the measured number; the measured number lies above the stated range.
By their numbers in this assay, from the lowest: compounds 3, 2, 1 and 4 (each within the scatter of the next, the first and the last beyond it).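

Adding methoxy on the saturated chain carbon bound to an oxygen on the aromatic ring moved the number beyond the scatter in this assay (a 2.7-fold higher number from compound 3 to compound 4 (0.42 log units; beyond the scatter)), a modest shift towards weaker inhibition, whereas fluoro, hydroxy and methoxy had stayed within it. Going by these compounds alone, the comparison with the hydroxy compound also clears the scatter, though only modestly (a 2.0-fold higher number from compound 2 to compound 4 (0.31 log units; beyond the scatter)), while the one with the fluoro compound does not (a 2.0-fold higher number from compound 1 to compound 4 (0.30 log units; within the scatter)). Nothing measured here accounts for this shift. Going by these compounds, how an amine or a carboxylic acid on this chain would behave remains open.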